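A few compounds are considered here, and "the series" means these few. Any claim that something is new, unique, unknown or untested is made for them only; others in the source may bear on it.

Of the compounds shown here, three of a shared core have been tested in a functional assay on HeLa cells (Homo sapiens) for antiproliferative activity, with a stated time of 24 h; a higher number here means a weaker inhibitor, a lower number a stronger inhibitor. Compound 1 `NC(=O)c1c(NC(=O)c2ccc(C(F)(F)F)cc2)sc2c1CCN(Cc1c(Cl)cccc1Cl)C2` gives > 50000 nM, which is a limit of the assay rather than a number. Compound 2 `COc1ccccc1NC(=S)N1CCc2c(sc(NC(=O)c3ccccc3Cl)c2C(N)=O)C1` gives > 50000 nM, again a limit and not a number. Compound 3 `NC(=O)c1c(NC(=O)c2ccccc2Cl)sc2c1CCN(C(=S)Nc1cc(C(F)(F)F)cc(C(F)(F)F)c1)C2` is the only one of the three with a measured number, giving 48900 nM in this assay; the other two sit at the limit of > 50000 nM in this assay, at which 2 of the 3 values shown sit.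

Compound 4 `NC(=O)c1c(NC(=O)c2ccc(C(F)(F)F)cc2)sc2c1CCN(C(=S)Nc1cc(C(F)(F)F)cc(C(F)(F)F)c1)C2` has not yet been measured. It differs from compound 3 in one place: 4-(trifluoromethyl)phenyl in place of 2-chlorophenyl on a carbonyl carbon. Among the measured compounds shown here, no measured pair shows this same change on its own. Compound 1 already carries the 4-(trifluoromethyl)phenyl group, with a different group on the ring nitrogen, and gives > 50000 nM. On that basis the step of a 1.0-fold higher number from compound 3 to compound 4 (0.01 log units; within the scatter) is expected to be none beyond the scatter, with a real chance that only a limit is reported. Compound 4 is therefore estimated at 50000 nM, in a range from 20000 nM to 150000 nM.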

Compound 4, half-maximal inhibitory concentration: 49000 nM
Compound 4: middle estimate off by 1.0-fold (0.01 log units), on the high side, and the stated range covers the measured number.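

Replacing 2-chlorophenyl with 4-(trifluoromethyl)phenyl on the carbonyl carbon gives, in this assay, a 1.0-fold higher number from compound 3 to compound 4 (0.00 log units; within the scatter). Among the compounds shown here, this is the first pair to isolate a change at this position, and it shows that these two aromatic groups cannot be told apart here, even though the entering group is the larger by heavy-atom count. Little more can be drawn from this comparison, which sits at the weak end of the scale: the limit of > 50000 nM in this assay, at which 2 of the 4 values shown sit.

Going by these compounds, whether any group on this carbonyl carbon can bring the number down remains open. The compounds shown do not tell how a phenyl ring carrying an amine or a carboxylic acid, or a longer alkyl chain in place of the ring, would read in this assay.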